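The source may hold more compounds than are shown below. What is called first, only, known or untested is meant among the compounds shown, and "the series" means these compounds.

Compound 1 `COc1cc(-c2ccnc3cc(-c4cn(CO)c5ccccc45)nn23)cc(OC)c1OC` gives 167 nM
Compound 2 `COc1cc(-c2ccnc3cc(-c4cn(C)c5ccccc45)nn23)cc(OC)c1OC` gives 1340 nM

In a functional assay on A549 cells (Homo sapiens) for inhibition, read by CCK-8 assay, with a stated time of 48 h (a lower number here means a stronger inhibitor, a higher number a weaker inhibitor), compound 2 gives 1340 nM as the higher of the two numbers. Compound 3 `COc1cc(-c2ccnc3cc(-c4cn(C(=O)OC(C)(C)C)c5ccccc45)nn23)cc(OC)c1OC` carries tert-butoxycarbonyl in place of methyl on an aromatic nitrogen, counted as tert-butoxycarbonyl in place of methyl on an aromatic nitrogen against compound 2. For the measured compounds named here, the only measured step bearing on this change is an 8.0-fold higher number from compound 1 to compound 2 (0.90 log units; beyond the scatter) and it is modest. Going by the values given here, no measured compound has a carbonyl on that nitrogen, so the direction is uncertain. For compound 3 the estimated step is a 2.2-fold lower number from compound 2 to compound 3 (0.35 log units; beyond the scatter) toward a lower number, smaller than the measured one. Compound 3 is expected at 600 nM within an estimated range of 130 nM to 2800 nM in this read-out.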

Compound 3, half-maximal inhibitory concentration: 2070 nM
Beside the measured number, compound 3's estimate is 3.5-fold (0.54 log units) below it; low and high end bracket the measured number.
By their numbers in this assay, from the lowest: compound 1; then compounds 2 and 3 (each within the scatter of the next).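

In this assay, tert-butoxycarbonyl and methyl on the aromatic nitrogen cannot be told apart, with a 1.5-fold higher number from compound 2 to compound 3 (0.19 log units; within the scatter) as the step, even though tert-butoxycarbonyl brings a carbonyl and more heavy atoms. Against hydroxymethyl the same group gives a 12-fold higher number from compound 1 to compound 3 (1.09 log units; beyond the scatter) as its step, so among these three compounds only compound 1 stands apart at this position. Nothing at hand explains these numbers. On these data alone, whether a longer chain such as 2-hydroxyethyl, or an aminomethyl group, on this nitrogen would match compound 1 remains open.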